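Adding a Fused Ring to Compound 3

The source may report more compounds than this note shows. Statements on the series, on what has been measured and on what is new or still open speak of the compounds shown alone.

In a physicochemical assay for lipophilicity, using the shake flask method, measured as octanol-water partition, at pH 7.4 (on this read-out higher numbers stand for higher lipophilicity and lower numbers for lower lipophilicity), compound 3 (`CC(=O)N[C@@H]1CCC[C@H](C(=O)Nc2cc(-c3cnc(C)n3C)c(Cl)cn2)C1`) gives 2.2, the lowest of the three numbers. Compound 2 (`CC(=O)N[C@@H]1CCC[C@H](C(=O)Nc2cc(-c3cnn(C)c3C)c(Cl)cn2)C1`) gives 2.6, and compound 1 (`CC(=O)N[C@@H]1CCC[C@H](C(=O)Nc2cc(-c3cnn4c3CCCC4)c(Cl)cn2)C1`) gives 3.2. Compound 4 (`CC(=O)N[C@@H]1CCC[C@H](C(=O)Nc2cc(-c3cnc4ccccn34)c(Cl)cn2)C1`) replaces the 1,2-dimethyl-1H-imidazol-5-yl group of compound 3, and the change is a group of 9 heavy atoms (7 carbon, 2 nitrogen; one five-membered aromatic ring with 2 hetero atoms, one six-membered aromatic ring with 1 hetero atom) in place of a group of 7 heavy atoms (5 carbon, 2 nitrogen; one five-membered aromatic ring with 2 hetero atoms), on an aromatic carbon. Two measured steps run the opposite way in size, from a larger group with two rings to a smaller group with one: a number 0.60 log units lower from compound 1 to compound 2 (beyond the scatter) and a number 1.00 log units lower from compound 1 to compound 3 (beyond the scatter). Both are modest and lie beyond the scatter. The choice of smaller group also matters, as a number 0.40 log units lower from compound 2 to compound 3 (beyond the scatter) shows. Among the measured compounds shown here, no measured compound carries a group with the six-membered aromatic ring that enters here, so these steps are only a partial guide. A modest rise in this assay is therefore expected, and the expected step is a number 0.50 log units higher from compound 3 to compound 4 (beyond the scatter). For compound 4 the estimated value is 2.7, with an expected range from 2.3 to 3.1.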

Compound 4, distribution coefficient: 3
Compound 4: the middle estimate sits 0.30 log units below what was measured; low and high end bracket the measured number.
By their numbers in this assay, from the lowest: compound 3; then compound 2; then compounds 4 and 1 (each within the scatter of the next).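

In this assay the fused aromatic group on the aromatic carbon opposite the ring nitrogen gives a number 0.80 log units higher from compound 3 to compound 4 (beyond the scatter) and also a number 0.40 log units higher from compound 2 to compound 4 (beyond the scatter), both modest steps. Against the group of compound 1, which has the same heavy-atom count but a non-aromatic six-membered ring, the result is a number 0.20 log units lower from compound 1 to compound 4 (within the scatter), so the aromatic and non-aromatic versions of the second ring cannot be told apart here. Among these four compounds, both two-ring groups now stand above both one-ring groups, with no exception, which compound 1 alone could not show.

No measurement on hand accounts for these numbers. From the compounds shown here alone, it remains open whether a methyl, methoxy or amine on the six-membered aromatic ring of compound 4 would shift the number, and whether a fused group with a different arrangement of its two ring nitrogens would behave as compound 4 does.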